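Testing a group swap on compound 1

The source may hold more compounds than are shown below. What is called first, only, known or untested is meant among the compounds shown, and "the series" means these compounds.

Going by the values given here, in a functional assay on MCF7 cells (Homo sapiens) for inhibition, read by sulforhodamine B assay (on this read-out higher numbers stand for weaker inhibition of growth and lower numbers for stronger inhibition of growth), compound 1 (`COc1ccc(-c2ccc(-c3ccc(-c4nc5cc(C)ccc5[nH]4)cc3)cc2)cc1OC`) gives 190 nM and stands lowest of the two numbers measured so far. Compound 2 (`COc1ccc(-c2ccc(-c3ccc(-c4nc5ccccc5[nH]4)cc3)cc2)cc1OC`) gives 7600 nM and has a hydrogen where compound 1 has a methyl. Compound 3 (`Cc1ccc2[nH]c(-c3ccc(-c4ccc(-c5ccc(C(F)(F)F)cc5)cc4)cc3)nc2c1`) keeps that methyl and instead carries 4-(trifluoromethyl)phenyl in place of 3,4-dimethoxyphenyl (4-(trifluoromethyl)phenyl in place of 3,4-dimethoxyphenyl on an aromatic carbon). Among the compounds with values here, the only measured step is a 40-fold higher number from compound 1 to compound 2 (1.60 log units; beyond the scatter) and it is large. It concerns a different place in the molecule, so it gives no direct guide to this swap. It shows only that a single small edit moved the number a long way in this pair. Within the data shown here, no measured compound tests a replacement of 3,4-dimethoxyphenyl, so the expectation is loose. With the starting point at the low end of the two numbers, a rise seems likelier than a fall, and the expected size is a 2.4-fold higher number from compound 1 to compound 3 (0.37 log units; beyond the scatter) with wide uncertainty. In this assay the estimated value for compound 3 is 450 nM with an expected range from 90 nM to 2500 nM as a working guess.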

Compound 3, concentration for 50% growth inhibition: 31000 nM
Compound 3: middle estimate off by 69-fold (1.84 log units), on the low side; measured number outside the range, above it.
By their numbers in this assay, from the lowest: compound 1; then compound 2; then compound 3.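

In this assay, replacing 3,4-dimethoxyphenyl with 4-(trifluoromethyl)phenyl gives a 160-fold higher number from compound 1 to compound 3 (2.21 log units; beyond the scatter), so the far end of the molecule matters to this read-out, just as the methyl does, whose loss gave a 40-fold higher number from compound 1 to compound 2 (1.60 log units; beyond the scatter). Both groups have the same heavy-atom count and one six-membered aromatic ring of carbon only, so that count does not separate them; what changes is that oxygen gives way to fluorine, and the counted hydrogen-bond acceptors go from 2 to 0. Going by these compounds alone, nothing available explains why this single swap moves the number so far.

The swap removes two methoxy groups and adds a trifluoromethyl group in one edit, so the compounds shown leave open which of these drives the rise, and a plain phenyl or a 4-methoxyphenyl group here would begin to separate the two. Also open, on these data alone, is whether an amine or a carboxylic acid on this ring would keep the number close to that of compound 1, and whether the methyl has the same large influence when 4-(trifluoromethyl)phenyl is present.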